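From Chloro to Carbamoyloxy on a Shared Core

The source may report more compounds than this note shows. Statements on the series, on what has been measured and on what is new or still open speak of the compounds shown alone.

In a functional assay on V79-379A cells (Cricetulus griseus) for cytotoxicity, read by MTT assay, in the presence of a further agent that is not named here (a lower number here means a stronger inhibitor, a higher number a weaker inhibitor), compound 1 `COC1=CC(=O)c2c(c(CCl)cn2C)C1=O` gives 33000 nM, the middle of three numbers. Compound 2 `COC1=CC(=O)c2c(c(COC(=O)c3ccc(F)cc3)c(C)n2C)C1=O` gives a much lower 300 nM, and compound 3 `COC1=CC(=O)c2c(c(COCc3ccccc3)c(C)n2C)C1=O` gives a higher 410000 nM; both gaps from compound 1 lie beyond the scatter. Compound 4 `COC1=CC(=O)c2c(c(COC(N)=O)cn2C)C1=O` has carbamoyloxy in place of chloro on a saturated chain carbon bound to an aromatic carbon. Its new group contains a carbonyl, as does the matching chain of compound 2 at 300 nM, while that of compound 3 at 410000 nM does not. These two compounds also differ elsewhere, so the evidence is thin. In this assay, the expected step is a moderate one towards stronger inhibition, a 3.3-fold lower number from compound 1 to compound 4 (0.52 log units; beyond the scatter). For compound 4, the estimated value is 10000 nM, with an expected range of 1500 nM to 60000 nM.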

Compound 4, half-maximal inhibitory concentration: 40 nM
For compound 4 the middle estimate is 250-fold (2.40 log units) above the measured one; measured number outside the range, below it.
By their numbers in this assay, from the lowest: compound 4; then compound 2; then compound 1; then compound 3.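

In this assay, carbamoyloxy in place of chloro on a saturated chain carbon bound to an aromatic carbon brings an 830-fold lower number from compound 1 to compound 4 (2.92 log units; beyond the scatter). Compound 1 and compound 4 differ in this one place only, so this single change on the shared core is enough to produce a large step. No measurement shown here explains why the step is so large. Open questions remain: how would an acetoxy group or a methoxy group on the same carbon compare, and does the carbamoyloxy nitrogen matter?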